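Series notes: aryl methyl step from compound 3 to compound 4

The compounds below may be only part of what the source reports. "The series", "measured", "known", "first", "only" and "open" are said of these compounds alone.

Measured so far in an assay on isolated protein for inhibition of matrix metalloproteinase-9 (Homo sapiens); a higher number here means a weaker inhibitor, a lower number a stronger inhibitor:
- compound 1 `C=C[C@@H]1OC(/C=C/c2ccc(Br)cc2)=N[C@H]1CO`; compound 1 gives 22000 nM.
- compound 2 `C=C[C@@H]1OC(CCCCC)=N[C@H]1CO`; compound 2 sits at an assay limit, not a number: > 2000000 nM.
- compound 3 `C=C[C@@H]1OC(c2ccccc2)=N[C@H]1CO`; compound 3 sits at an assay limit, not a number: > 4000000 nM.

Of the three values in this assay, only compound 1 gives a number. Compound 3 stands at a limit, namely (the limit of > 4000000 nM in this assay, at which 1 of the 3 values shown sits). Compound 2 likewise stands at a limit, namely (the limit of > 2000000 nM in this assay, at which 1 of the 3 values shown sits). Going by the values given here, no two measured compounds differ in one place, so no measured step size is available for this assay, and the ranking of compound 3 against the others cannot be told beyond its limit.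

Compound 4 `C=C[C@@H]1OC(c2ccc(C)cc2)=N[C@H]1CO` differs from compound 3 by methyl in place of hydrogen on an aromatic carbon. Among the compounds with values here, with compound 3 at a limit and no measured step to lean on, the step expected in this assay is a number no higher from compound 3 to compound 4 (the limit leaves the size open), which is taken as none beyond the scatter in either direction. Compound 4 is estimated at 4000000 nM, with a range from 500000 nM to 20000000 nM, and it is expected that the assay again reports only a limit.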

Compound 4, inhibition constant: 68000 nM
Compound 4: the middle estimate sits 59-fold (1.77 log units) above what was measured; measured number below the stated range.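

In this assay, methyl in place of hydrogen on an aromatic carbon, para to a group of 9 heavy atoms, gives an at least 58-fold lower number from compound 3 to compound 4 (1.76 log units; beyond the scatter), which shows that this position responds strongly to this one-carbon change. Going by these compounds alone, this is the first measured change on the aromatic ring, and it makes compound 4 the second compound to give a number rather than a limit. Compound 3 stands at a limit, so the size of the step is open on one side: the limit of > 4000000 nM in this assay, at which 1 of the 4 values shown sits.

Going by these compounds, whether a chlorine, a methoxy group or a longer chain at the same place would lower the number further remains open, as does the effect of methyl on the other ring carbons. Within the data shown here, compound 1 and compound 4 differ in more than one place, so no step links them.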